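The source may report more compounds than this note shows. Statements on the series, on what has been measured and on what is new or still open speak of the compounds shown alone.

Measured so far:
compound 2 `C=CC[C@@H]1C[C@@H](c2ccc(Cl)c(Cl)c2)[C@H](NC(=O)c2cc(-c3c(Cl)cnn3C)c(Cl)o2)CN1` — 160 nM
compound 3 `CNC(=O)C[C@@H]1C[C@@H](c2ccc(F)c(F)c2)[C@H](NC(=O)c2cc(-c3c(Cl)cnn3C)c(Cl)o2)CN1` — 50 nM
compound 1 `CC(=O)OCC[C@@H]1C[C@@H](c2ccc(F)c(F)c2)[C@H](NC(=O)c2cc(-c3c(Cl)cnn3C)c(Cl)o2)CN1` — "not determined" (no result reported)

In a functional assay on LNCaP cells (Homo sapiens) for antiproliferative activity (a higher number here means a weaker inhibitor, a lower number a stronger inhibitor), compound 2 gives the higher of the two numbers; compound 3 sits lower by a gap beyond the scatter. Compound 1 has no number, so nothing can be said of it here. Compound 4 `Cn1ncc(Cl)c1-c1cc(C(=O)N[C@@H]2CN[C@H](CCO)C[C@H]2c2ccc(Cl)c(Cl)c2)oc1Cl` is not yet measured. It differs from compound 2 in one place: hydroxymethyl in place of vinyl on a saturated chain carbon bound to a saturated ring carbon. Going by the values given here, no measured pair shows this change, so the size of the step rests on the two numbers alone. A small step toward a lower number is expected, hardly beyond the scatter, given as a 1.6-fold lower number from compound 2 to compound 4 (0.20 log units; within the scatter). Compound 4 is estimated at 100 nM, with a range from 40 nM to 300 nM.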

Compound 4, half-maximal inhibitory concentration: 160 nM
The estimate for compound 4 lay 1.6-fold (0.20 log units) below the measured number, within the range that was stated.
By their numbers in this assay, from the lowest: compound 3; then compounds 2 and 4 (each within the scatter of the next).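

In this assay, hydroxymethyl in place of vinyl on a saturated chain carbon bound to a saturated ring carbon gives no change at the digits printed from compound 2 to compound 4 (within the scatter). At this position, the allyl to 2-hydroxyethyl change therefore brings in a hydrogen-bond donor and acceptor without a readable shift in the number. Nothing measured here bears on why the step is flat.

Compound 3 differs from compound 4 in more than one place, so its lower number cannot be assigned to its chain. On these data alone, whether an amine, a carboxylic acid or a longer chain would also hold the number at this position remains open.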